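The source may report more compounds than this note shows. Statements on the series, on what has been measured and on what is new or still open speak of the compounds shown alone.

In a functional assay on the whole organism for antagonist activity, with Mus musculus as the target (on this read-out lower numbers stand for an effect already at smaller amounts and higher numbers for an effect only at larger amounts of compound), compound 3 `COC(=O)N(C)C(C)C#CCn1ccnc1` gives > 100 mg/kg, which is a limit and not a number. Compound 2 `COC(=O)N(C)C(C)C#CCN1CCCC1` gives > 100 mg/kg, the same limit. Compound 1 `COC(=O)N(C)CC#CCN(C)C`, which also carries dimethylamino, gives > 30 mg/kg, again a limit. Compound 3 therefore has no exact value, and neither do the two compounds it can be compared with.

Compound 4 `COC(=O)N(C)C(C)C#CCN(C)C` differs from compound 3 in one group, on a saturated chain carbon bound to a triple-bonded carbon: dimethylamino in place of 1H-imidazol-1-yl on a saturated chain carbon bound to a triple-bonded carbon. For the measured compounds named here, the one measured step at this place is a step that the two limits leave unreadable from compound 2 to compound 3, in which 1H-imidazol-1-yl stands in place of pyrrolidin-1-yl. It gives no size to carry over, so any forecast here is loose. The only hint is the lower limit of compound 1 at > 30 mg/kg, which comes with the same dimethylamino group. On that slim ground, a modest shift toward smaller doses is expected, the estimated change being an at least 1.4-fold lower number from compound 3 to compound 4 (0.15 log units; that floor lies within the scatter). Another limit would be no surprise. In this assay, compound 4 is estimated at 70 mg/kg, with an expected range of 20 mg/kg to 200 mg/kg.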

Compound 4, dose for half-maximal effect: > 100 mg/kg
Compound 4 ended at the assay's limit; the forecaster's own chance of this, stated with the estimate: 65%; at least 1.4-fold (0.15 log units) between middle value and limit.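

No step can be read between compound 4 and compound 1, compound 2 or compound 3 in this assay; all four values are limits, not numbers. As far as these compounds go, whether dimethylamino, pyrrolidin-1-yl or 1H-imidazol-1-yl, or methyl in place of hydrogen, changes the effective dose at all stays open.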